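From Hydrogen to Bromophenylamino on a Shared Core

A few compounds are considered here, and "the series" means these few. Any claim that something is new, unique, unknown or untested is made for them only; others in the source may bear on it.

Compound 1 `CCN1CCc2c(sc(NC=O)c2C(N)=O)C1` carries a hydrogen on the carbonyl carbon attached to its core and an ethyl group on the ring nitrogen. In a functional assay (strain AB) with Danio rerio as the target, read by microscopy, with a stated time of 1 h (a higher number here means that more compound is needed for the effect, a lower number that less compound is needed), compound 1 gives only a limit, > 25000 nM, and not a number. Compound 1 therefore sits at the limit of > 25000 nM in this assay, at which 1 of the 3 values shown sits. Compound 2 `CC(C)(C)C[N+]1(C)CCc2c(sc(NC(=O)Nc3ccc(Cl)cc3)c2C(N)=O)C1` and compound 3 `C[N+]1(CC2CCCC2)CCc2c(sc(NC(=O)Nc3ccc(Cl)cc3)c2C(N)=O)C1` share the same core but carry a (4-chlorophenyl)amino on that carbonyl carbon and a quaternary ring nitrogen. In this assay compound 2 gives 290 nM and compound 3 gives 200 nM. Among the measured compounds shown here, the single measured step, a 1.5-fold lower number from compound 2 to compound 3 (0.16 log units; within the scatter), concerns only the group on the ring nitrogen and lies within the scatter; it does not touch the change considered here. Compound 4 `CCN1CCc2c(sc(NC(=O)Nc3ccc(Br)cc3)c2C(N)=O)C1` differs from compound 1 by (4-bromophenyl)amino in place of hydrogen on a carbonyl carbon. For the measured compounds named here, no measured pair isolates this change. What the data show is that the two compounds bearing an arylamino on the carbonyl carbon give numbers, while compound 1 without one gives only a limit, so a large fall in the number is expected, though compound 4 keeps the ethyl group on an uncharged ring nitrogen, and the size of the fall is uncertain. Compound 4 is expected to give about 1500 nM in this assay, between 300 nM and 8000 nM. This expectation amounts to an at least 16-fold lower number from compound 1 to compound 4 (1.22 log units; beyond the scatter).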

Compound 4, half-maximal effective concentration: 3130 nM
For compound 4 the middle estimate is 2.1-fold (0.32 log units) below the measured one; the measured number falls inside the stated range.
By their numbers in this assay, from the lowest: compounds 3 and 2 (each within the scatter of the next); then compound 4. At a limit, above all of these: compound 1.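

Among the compounds shown here, with compound 4, the change at this position can for the first time be read in a pair of compounds that differ in one place: in this assay, (4-bromophenyl)amino in place of hydrogen on a carbonyl carbon gives an at least 7.9-fold lower number from compound 1 to compound 4 (0.90 log units; beyond the scatter). The ethyl group on the ring nitrogen stays the same across this pair, so among the compounds shown a measured number is not confined to those with a quaternary ring nitrogen. The full size of the step remains unknown, as its starting point is a limit and not a number: the limit of > 25000 nM in this assay, at which 1 of the 4 values shown sits.

The compounds shown do not tell whether the step needs the bromine, the phenyl ring or only the amino group on the carbonyl carbon, a question that a plain phenylamino or a methylamino in the same place would bear on. Nor do they give a direct comparison of (4-bromophenyl)amino with (4-chlorophenyl)amino, as compound 2 and compound 3 each differ from compound 4 in the group on the ring nitrogen as well.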